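One More Carbon on the Chain: Cytotoxicity Outlook

The compounds below may be only part of what the source reports. "The series", "measured", "known", "first", "only" and "open" are said of these compounds alone.

Compound 1 `CCCCCNc1cnc(C(=O)NCc2ccccc2)cn1`: > 100000 nM
Compound 2 `CCCCCCNc1cncc(C(=O)NCc2ccccc2)n1`: 20000 nM
Compound 3 `O=C(NCc1ccccc1)c1nccnc1Cl`: "not determined" (no result reported)

Within the data shown here, in an ADME assay on MDCK cells (Canis lupus familiaris) for cytotoxicity, read by microscopy, with a stated time of 6 days (a lower number here means that less compound is tolerated, a higher number that more compound is tolerated), compound 2 gives 20000 nM, the only plain number among the three measured compounds. For compound 1 the result is a limit, > 100000 nM, the assay ceiling at which one of the three values sits (the limit of > 100000 nM in this assay, at which 1 of the 3 values shown sits). In this assay compound 3 gives "not determined" (no result reported). Compound 4 `CCCCCCCNc1cncc(C(=O)NCc2ccccc2)n1` differs from compound 2 by methyl in place of hydrogen on a saturated chain carbon, six bonds along the chain from a nitrogen on an aromatic ring. Among the measured compounds shown here, no pair of measured compounds differs in a single place, so no measured step shows how large such a change is. In this assay a step no larger than the usual scatter is expected, estimated as a 1.3-fold lower number from compound 2 to compound 4 (0.12 log units; within the scatter). Compound 4 is therefore expected to give 15000 nM, within the range 5000 nM to 60000 nM.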

Compound 4, minimum cytotoxic concentration: 4000 nM
Beside the measured number, compound 4's estimate is 3.8-fold (0.57 log units) above it, and the stated range ends above it.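

In this assay, among these compounds, methyl in place of hydrogen on a saturated chain carbon, six bonds along the chain from a nitrogen on an aromatic ring, gives a 5.0-fold lower number from compound 2 to compound 4 (0.70 log units; beyond the scatter) and is the first change at a single place that can be read here. One added carbon at this position is therefore enough to move the tolerated concentration beyond the scatter. Nothing measured here gives a reason for the change. On these data alone, whether a longer chain would lower the number further, or an amine or a carboxylic acid on this carbon would raise it again, stays open.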